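This account rests on a few compounds, and the source may have more. Where it says the series, first, only, none or still open, it means among the compounds named here.

Measured so far in an in vitro assay on U2OS cells for agonist activity at neurotensin receptor type 2 (Homo sapiens), read by reporter gene assay and beta-arrestin recruitment; a lower number here means that less compound is needed, a higher number that more compound is needed for the effect:
compound 1, `COc1cc2nc(C3CCC3)nc(N3CCN(c4ccccc4F)CC3)c2cc1OC`: > 80000 nM, a limit of the assay
compound 2, `COc1cc2nc(C)nc(N3CCN(c4ccccc4OC)CC3)c2cc1OC`: > 80000 nM, a limit of the assay

Compound 2 stands at the assay limit only; no number is known for it. The other measured compound sits at the same limit, as the limit of > 80000 nM in this assay, at which 2 of the 2 values shown sit, records. Compound 3, `CCc1nc(N2CCN(c3ccccc3OC)CC2)c2cc(OC)c(OC)cc2n1`, differs from compound 2 by methyl in place of hydrogen on a saturated chain carbon bound to an aromatic carbon, so that methyl becomes ethyl. For the measured compounds named here, with no measured step in hand and both measured values at the limit, no change beyond the scatter is expected for a number no higher from compound 2 to compound 3 (the limit leaves the size open). Compound 3 is therefore estimated at 80000 nM, within 20000 nM to 300000 nM, and most likely again reported only as a limit.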

Compound 3, half-maximal effective concentration: > 80000 nM
Compound 3: only a limit was reported; the forecaster's own chance of this, stated with the estimate: 70%; the middle value lies on the limit itself.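

In this assay no step can be read between compound 2 and compound 3, because both stand only at a limit: the limit of > 80000 nM in this assay, at which 3 of the 3 values shown sit.

The compounds shown leave open whether any change on the shared core gives a measurable value.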